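Replacing Acetyl with Ethyl on a Shared Core

A few compounds are considered here, and "the series" means these few. Any claim that something is new, unique, unknown or untested is made for them only; others in the source may bear on it.

Measured in a functional assay on HaCaT cells (Homo sapiens) for antiproliferative activity, read by sulforhodamine B assay, with a stated time of 3 days; on this read-out higher numbers stand for weaker inhibition and lower numbers for stronger inhibition:
Compound 1 `COC(=O)c1cc(CCc2ccccc2OC)ccc1O`: 20000 nM
Compound 2 `COC(=O)c1cc(CCc2cc(C(C)=O)ccc2OC)ccc1O`: 660 nM

Compound 2 holds the lower of the two numbers, so it is the stronger inhibitor of this pair. The next compound to be tested, compound 3 `CCc1ccc(OC)c(CCc2ccc(O)c(C(=O)OC)c2)c1`, differs from it at one place: ethyl in place of acetyl on an aromatic carbon.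

For the measured compounds named here, one measured step bears on this change. At that same carbon, acetyl in place of hydrogen gave a 30-fold lower number from compound 1 to compound 2 (1.48 log units; beyond the scatter), a large step. Compound 3 keeps a group at that carbon but loses the acetyl itself. Going by the values given here, no measured compound shows how ethyl behaves there, so the expectation is loose. Part of the large step is expected to be given back, which would put the number for compound 3 between those of the two measured compounds. The expected change is a 4.5-fold higher number from compound 2 to compound 3 (0.66 log units; beyond the scatter), an estimated rise in the number. In this assay compound 3 is estimated at 3000 nM (expected range 800 nM to 12000 nM) .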

Compound 3, half-maximal inhibitory concentration: 430 nM
Compound 3: the middle estimate sits 7.0-fold (0.84 log units) above what was measured; the whole stated range lies above it.
By their numbers in this assay, from the lowest: compounds 3 and 2 (each within the scatter of the next); then compound 1.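

In this assay, ethyl in place of acetyl on this aromatic carbon, which is para to a methoxy group, gives a 1.5-fold lower number from compound 2 to compound 3 (0.19 log units; within the scatter), so compound 2 and compound 3 cannot be told apart here and the carbonyl of the acetyl is not needed to keep the number low. Ethyl in place of hydrogen at the same carbon gives a 47-fold lower number from compound 1 to compound 3 (1.67 log units; beyond the scatter), a large step that shows the gain seen earlier with acetyl does not belong to acetyl alone but also appears with a group that has no hydrogen-bond acceptor and no double bond outside the aromatic rings. Nothing available explains why the two groups give such similar numbers, and no measurement beyond these values bears on the result.

The compounds shown leave open whether a smaller methyl, a longer propyl chain or a group of another kind, such as an amine or a carboxylic acid, would keep the number at this level on the same carbon. They also leave open whether ethyl and acetyl would stay level in any assay other than this assay.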